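Removing the Ortho Fluoro from a Dimethoxyphenyl Thiophene Amidine

The source may hold more compounds than are shown below. What is called first, only, known or untested is meant among the compounds shown, and "the series" means these compounds.

Compound 1, `N=C(N)c1ccc(-c2ccc(-c3ccc(Cl)cc3)s2)cc1F`: 1500 nM
Compound 2, `COc1cc(OC)cc(-c2ccc(-c3ccc(C(=N)N)c(F)c3)s2)c1`: 1860 nM

In a functional assay on SK-MEL-2 cells (Homo sapiens) for inhibition, read by sulforhodamine B assay, with a stated time of 48 h (a higher number here means a weaker inhibitor of growth, a lower number a stronger inhibitor of growth), compound 2 gives the highest of the two numbers, yet its nearest neighbour is compound 1, whose value lies within the scatter, so the two cannot be ordered. Compound 3, `COc1cc(OC)cc(-c2ccc(-c3ccc(C(=N)N)cc3)s2)c1`, differs from compound 2 by hydrogen in place of fluoro on an aromatic carbon. Within the data shown here, no measured pair shows the effect of this change, so the step is expected to be small and not clearly beyond the scatter, a 1.1-fold higher number from compound 2 to compound 3 (0.03 log units; within the scatter). Compound 3 is therefore estimated at 2000 nM in this assay, within 900 nM to 4500 nM.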

Compound 3, concentration for 50% growth inhibition: 1950 nM
The estimate for compound 3 lay 1.0-fold (0.01 log units) above the measured number; measured number inside the range.
By their numbers in this assay, from the lowest: compounds 1, 2 and 3 (each within the scatter of the next).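

In this assay, hydrogen in place of fluoro on this aromatic carbon gives a 1.0-fold higher number from compound 2 to compound 3 (0.02 log units; within the scatter) and stays within the scatter. This first measured pair at the position shows that, with the shared core of compound 2 and compound 3, fluoro and hydrogen cannot be told apart by growth inhibition. No evidence at hand bears on the reason. Still open, on these data alone, is whether a larger group on this carbon, such as an amine or a hydroxyl, would shift the number, and whether the same exchange behaves alike in compound 1.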